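A few compounds are considered here, and "the series" means these few. Any claim that something is new, unique, unknown or untested is made for them only; others in the source may bear on it.

Compound 2 `COc1ccccc1-c1cn2ccnc2c(-c2ccc3ncn(C4CCCCC4)c3c2)n1` shares its core with compound 1 `c1ccc(-c2cn3ccnc3c(-c3ccc4ncn(C5CCCCC5)c4c3)n2)cc1`. In a functional assay on NCI-H226 cells (Homo sapiens) for inhibition, read by sulforhodamine B assay, with a stated time of 48 h, tested at 10 uM (a higher number here means more inhibition at the concentration tested (going by the name of the read-out), a lower number less inhibition), compound 1 gives 33.9%, and in this assay compound 2 gives 25.7%. Among the two measured numbers compound 2 is nearest to compound 1, and the step of a number 8.2 percentage points lower from compound 1 to compound 2 (within the scatter) lies within the scatter, so the two compounds cannot be separated on these data. Compound 3 `c1csc(-c2cn3ccnc3c(-c3ccc4ncn(C5CCCCC5)c4c3)n2)c1` carries thiophen-2-yl in place of 2-methoxyphenyl on an aromatic carbon. Among the compounds with values here, the only measured step, a number 8.2 percentage points lower from compound 1 to compound 2 (within the scatter), changes a single substituent at the same place, whereas here the whole ring is exchanged, so it bears on the new step only loosely. Nothing measured points to a move beyond the scatter in either direction, and the step of a number 4.3 percentage points higher from compound 2 to compound 3 (within the scatter) is therefore expected to stay small. Compound 3 is estimated to give 30% in this assay, with a range from 15% to 48%.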

Compound 3, a percentage reported as inhibition, at one concentration (the size of the read-out at that concentration, not a potency): 17.1%
For compound 3 the middle estimate is 12.9 percentage points above the measured one; measured number inside the range.
By their numbers in this assay, from the lowest: compounds 3, 2 and 1 (each within the scatter of the next, the first and the last beyond it).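

Within the data shown here, exchanging phenyl for thiophen-2-yl on this aromatic carbon gives a number 16.8 percentage points lower from compound 1 to compound 3 (beyond the scatter), the first step at this position in this assay that clears the usual variation between repeated measurements. Against 2-methoxyphenyl, the same five-membered ring gives a number 8.6 percentage points lower from compound 2 to compound 3 (within the scatter), so on these data thiophen-2-yl is set apart from phenyl but not from 2-methoxyphenyl. The position therefore responds to at least one exchange of the whole ring, although these numbers describe inhibition at one concentration and are not potencies.

As far as these compounds go, how this position would respond to a pyridinyl ring, an amine or a carboxylic acid remains open, as does whether the thiophene would behave the same way if attached through its other ring carbon. Nothing measured here gives a reason for the gap between phenyl and thiophen-2-yl.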